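The compounds below may be only part of what the source reports. "The series", "measured", "known", "first", "only" and "open" are said of these compounds alone.

Measured so far in an assay on isolated protein for inhibition of Nitric oxide synthase, inducible (Homo sapiens), read by scintillation counting, with a stated time of 30 min, tested at 50 uM; on this read-out lower numbers stand for less inhibition and higher numbers for more inhibition at the one concentration tested (going by the name of the read-out):
compound 1 `CCCC(=O)N1N=C(c2cc(OC)ccc2N)SC1(C)C` gives 91.1%
compound 2 `CCCCC(=O)N1N=C(c2cc(OC)ccc2N)SC1(C)C` gives 101%
compound 3 `COc1ccc(N)c(C2=NN(C(=O)C3CC3)C(C)(C)S2)c1` gives 90.1%

Compound 1 stands second of the three numbers, within the scatter of compound 3 and of compound 2. Among the measured compounds shown here, every measured step concerns the acyl group: a number 9.9 percentage points higher from compound 1 to compound 2 (within the scatter), a number 1 percentage points lower from compound 1 to compound 3 (within the scatter) and the one step beyond the scatter, a number 10.9 percentage points lower from compound 2 to compound 3 (beyond the scatter). Compound 4 `CCCC(=O)N1N=C(c2ccccc2N)SC1(C)C` changes a different place: hydrogen in place of methoxy on an aromatic carbon. For the measured compounds named here, no measured step touches the aromatic ring, so none bears directly on this change, and the spread among the three acyl variants is small. The expectation is therefore a step of a number 9.1 percentage points lower from compound 1 to compound 4 (within the scatter), allowed to be downward but not clearly beyond the scatter. Compound 4 is expected to give 82%, between 55% and 100%.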

Compound 4, a percentage reported as inhibition, at one concentration (the size of the read-out at that concentration, not a potency): 35.2%
Estimate against measurement, compound 4: 46.8 percentage points above; the whole stated range lies above it.
By their numbers in this assay, from the lowest: compound 4; then compounds 3, 1 and 2 (each within the scatter of the next, the first and the last beyond it).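

In this assay, hydrogen in place of methoxy, para to an amino group, gives a number 55.9 percentage points lower from compound 1 to compound 4 (beyond the scatter). This shows that the read-out depends far more on this aromatic position than the steps among the acyl variants, compounds 1, 2 and 3, had suggested. Nothing measured on the compounds accounts for the size of this step.

As far as these compounds go, whether ethoxy, hydroxyl or fluorine at this place would keep the read-out of compound 1 remains open. Also open, from the compounds shown here alone, is whether the methoxy step would be as large with the cyclopropyl carbonyl of compound 3 or the longer chain of compound 2.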